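The source may report more compounds than this note shows. Statements on the series, on what has been measured and on what is new or still open speak of the compounds shown alone.

Of the compounds shown here, three built on a shared core have been tested in a functional assay on SEM cells (Homo sapiens) for cytotoxicity, with a stated time of 72 h; a higher number here means that more compound is needed for the effect, a lower number that less compound is needed. Compound 1 (`C=C[C@@](C)(/C=C/c1ccc(OC)cc1)CCC=C(C)C`) gives > 36600 nM, which is a limit and not a number. Compound 2 (`C=C[C@@](C)(/C=C/c1ccc(O)cc1)CCCO`) gives > 36600 nM, which is also a limit. Compound 3 (`C=C[C@@](C)(/C=C/c1ccc(O)cc1)CC/C=C/C(=O)OCc1ccccc1`) gives > 36600 nM, again a limit. Compound 2 therefore has no exact value and cannot be ranked against the other two, as the results show (the limit of > 36600 nM in this assay, at which 3 of the 3 values shown sit).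

Compound 4 (`C=C[C@@](C)(/C=C/c1ccc(O)cc1)CC/C=C/C#N`) has not yet been measured. It differs from compound 2 as follows: 2-cyanoethenyl in place of hydroxymethyl on a saturated chain carbon, three bonds along the chain from two double-bonded chain carbons. In short, 2-cyanoethenyl stands in place of hydroxymethyl on a saturated chain carbon. Going by the values given here, no measured step shows what such a change does in this assay. Among the compounds with values here, the only guide is that all three tested compounds stop at the same limit, so no change beyond the usual scatter is expected. The expected step is an at least 1.2-fold lower number from compound 2 to compound 4 (0.08 log units; that floor lies within the scatter), and it may well be reported only as a limit. For compound 4 the estimate is 30000 nM, with an expected range from 10000 nM to 36600 nM.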

Compound 4, half-maximal effective concentration: > 36600 nM
Compound 4 gave a limit, no number; the forecaster's own chance of this, stated with the estimate: 65%; middle value at least 1.2-fold (0.08 log units) away from the limit.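

Compound 4 gives a limit and not a number, as compound 2 does, so no step can be read between compound 2 and compound 4, as the results show: the limit of > 36600 nM in this assay, at which 4 of the 4 values shown sit.

The compounds shown leave open what swapping hydroxymethyl for 2-cyanoethenyl does in this assay, and what exact concentration any of these compounds needs for the effect.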